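The source may report more compounds than this note shows. Statements on the series, on what has been measured and on what is new or still open speak of the compounds shown alone.

Measured compounds:
compound 1 `COc1cc2nc(N3CCN(C(=O)c4ccc(Br)o4)[C@H]4CCCC[C@H]43)nc(N)c2cc1OC` — 3.47 nM
compound 2 `COc1cc2nc(N3CCN(C(=O)c4ccc(C(C)=O)o4)[C@H]4CCCC[C@H]43)nc(N)c2cc1OC` — 25.7 nM
compound 3 `COc1cc2nc(N3CCN(C(=O)c4ccc[nH]4)[C@H]4CCCC[C@H]43)nc(N)c2cc1OC` — 10.5 nM

In an assay on CHO cells for displacement of a labelled ligand from Alpha-1A adrenergic receptor (Homo sapiens) (on this read-out lower numbers stand for stronger inhibition and higher numbers for weaker inhibition), compound 2 gives the highest of the three numbers; compound 3 sits nearest, with a 2.4-fold lower number from compound 2 to compound 3 (0.39 log units; beyond the scatter), and compound 1 furthest, with a 7.4-fold higher number from compound 1 to compound 2 (0.87 log units; beyond the scatter) read in the other direction. Compound 4 `COc1cc2nc(N3CCN(C(=O)c4ccccc4)[C@H]4CCCC[C@H]43)nc(N)c2cc1OC` differs from compound 2 by phenyl in place of 5-acetylfuran-2-yl on a carbonyl carbon. For the measured compounds named here, no measured step exchanges the aryl group for a plain phenyl, so the bearing steps are indirect: removal of the acetyl-bearing furan in favour of a pyrrole, a 2.4-fold lower number from compound 2 to compound 3 (0.39 log units; beyond the scatter), and the bromo-to-acetyl exchange on the furan, a 7.4-fold higher number from compound 1 to compound 2 (0.87 log units; beyond the scatter), both of which leave compound 2 with the weakest number. A modest move toward lower numbers is therefore expected, a 2.6-fold lower number from compound 2 to compound 4 (0.41 log units; beyond the scatter). For compound 4 the estimate in this assay is 10 nM, with a range from 3 nM to 35 nM.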

Compound 4, inhibition constant: 4.17 nM
Estimate against measurement, compound 4: 2.4-fold (0.38 log units) above; low and high end bracket the measured number.
By their numbers in this assay, from the lowest: compounds 1 and 4 (each within the scatter of the next); then compound 3; then compound 2.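

In this assay, a heteroaryl group is not needed on the carbonyl carbon: phenyl gives a clear gain over both the acetyl-bearing furan (in a 6.2-fold lower number from compound 2 to compound 4 (0.79 log units; beyond the scatter)) and the pyrrole (in a 2.5-fold lower number from compound 3 to compound 4 (0.40 log units; beyond the scatter)). Phenyl and the 5-bromofuran-2-yl group cannot be separated (a 1.2-fold higher number from compound 1 to compound 4 (0.08 log units; within the scatter)). Nothing available explains these differences. Open questions are whether an amine or a methoxy group on the phenyl keeps this number, and whether a saturated ring such as cyclohexyl can replace the aromatic ring on this carbonyl carbon.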